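The compounds below may be only part of what the source reports. "The series", "measured", "known", "first", "only" and "open" are said of these compounds alone.

Compound 1 `CC(=O)N[C@@H](CSC(=O)Nc1ccccc1Cl)C(=O)O`: > 200000 nM (a limit)
Compound 2 `CC(=O)N[C@@H](CSC(=O)Nc1ccc(Br)cc1)C(=O)O`: 320 nM
Compound 3 `COc1ccccc1CNC(=O)SC[C@H](NC(C)=O)C(=O)O`: > 200000 nM (a limit)

All three were read in a functional assay on UACC-62 cells (Homo sapiens) for cytotoxicity, read by MTT assay, with a stated time of 6 days; on this read-out higher numbers stand for weaker inhibition and lower numbers for stronger inhibition. For the measured compounds named here, compound 2 gives the only true number, as the entries for compound 1 and compound 3 are limits.

Compound 4 `CC(=O)N[C@@H](CSC(=O)Nc1ccc(Cl)cc1)C(=O)O` differs from compound 2 in one place: chloro in place of bromo on an aromatic carbon, para to a large group. Going by the values given here, no measured pair shows this exchange, so the expectation rests on compound 2 at 320 nM. No step beyond the scatter is expected in this assay, and neither direction is favoured. The expected 1.3-fold higher number from compound 2 to compound 4 (0.10 log units; within the scatter) is small. The upper side stays wide for compound 4 because of the limit of > 200000 nM in this assay, at which 2 of the 3 values shown sit. Compound 4 is estimated at 400 nM, with an expected range of 100 nM to 4000 nM.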

Compound 4, half-maximal inhibitory concentration in the UACC-62 assay: 24 nM
Beside the measured number, compound 4's estimate is 17-fold (1.22 log units) above it, outside the stated range (below it).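

In the UACC-62 assay, the choice of halogen at this position, on an aromatic carbon para to a large group, clearly matters: chloro in place of bromo gives a 13-fold lower number from compound 2 to compound 4 (1.12 log units; beyond the scatter). In a physicochemical assay for solubility (a higher number here means a more soluble compound, a lower number a less soluble compound), compound 2 gives 50 ug/mL and compound 4 gives 721 ug/mL. The single-atom exchange also goes with higher solubility in the physicochemical assay: the measured solubility of compound 2, 50 ug/mL, and of compound 4, 721 ug/mL, a 14-fold higher number (1.16 log units; beyond the scatter)

A single pair cannot tell whether this solubility difference contributes to the step in the UACC-62 assay. Also open, on these data alone, is how fluoro, methyl or trifluoromethyl on the same aromatic carbon would read in either assay.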